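Replacing 4,4-Dimethylcyclohexyl with a 1,1-Dioxothian-4-yl Ring

The source may hold more compounds than are shown below. What is called first, only, known or untested is meant among the compounds shown, and "the series" means these compounds.

Of the compounds shown here, three with a shared core have been measured, and all differ only in the group on an aromatic nitrogen or in the linking amide. In an assay on HEK293 cells for activation of Kir3.1/Kir3.2 (Homo sapiens), read by thallium flux (on this read-out lower numbers stand for an effect already at smaller amounts and higher numbers for an effect only at larger amounts of compound), compound 1 `Cc1cc(NC(=S)Cn2nnc(-c3ccccc3)n2)n(C2CCCCC2)n1` gives 623 nM. Compound 3 `Cc1cc(NC(=O)Cn2nnc(-c3ccccc3)n2)n(C2CCCC2)n1` gives 163 nM in this assay. For compound 2 `Cc1cc(NC(=O)Cn2nnc(-c3ccccc3)n2)n(C2CCC(C)(C)CC2)n1` the assay this assay reports only a limit, > 221 nM, and not a number. Compound 2 therefore stands at the limit of > 221 nM in this assay, at which 1 of the 3 values shown sits. Going by the values given here, the one measured step at this position, an at least 1.3-fold lower number from compound 2 to compound 3 (0.13 log units; that floor lies within the scatter), changes the ring on the aromatic nitrogen.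

Compound 4 `Cc1cc(NC(=O)Cn2nnc(-c3ccccc3)n2)n(C2CCS(=O)(=O)CC2)n1` differs from compound 2 in one place: 1,1-dioxothian-4-yl in place of 4,4-dimethylcyclohexyl on an aromatic nitrogen. Among the compounds with values here, no measured step involves the entering 1,1-dioxothian-4-yl group, and the only step at this position starts from a limit and has a floor within the scatter. Nothing here points to a direction beyond the scatter for this assay. Compound 4 is expected at 500 nM in this assay, within a range of 150 nM to 2500 nM. This expectation corresponds to a step that the limit leaves unreadable from compound 2 to compound 4, which is uncertain in both direction and size.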

Compound 4, half-maximal effective concentration: > 10000 nM
Compound 4: no number, only a limit; the forecaster's own chance of this, stated with the estimate: 40%; at least 20-fold (1.30 log units) between middle value and limit.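

In this assay compound 4 gives only a limit, > 10000 nM, and not a number. Putting the 1,1-dioxothian-4-yl ring in place of cyclopentyl on the aromatic nitrogen gives an at least 61-fold higher number from compound 3 to compound 4 (1.78 log units; beyond the scatter), so this position does not tolerate every ring equally. The earlier compounds shown here showed no step at this position beyond the scatter, while the step between compound 2 and compound 4 cannot be read.

Still open, on these data alone, is what in the entering ring matters, whether its sulfur with the two oxygens or simply a hetero atom in the ring, and a tetrahydropyran-4-yl ring or a piperidin-4-yl ring, which carries an amine, would help separate these. As far as these compounds go, how far the true value of compound 4 lies from its limit also stays unknown.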